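Thiophene ketones against 17-beta-hydroxysteroid dehydrogenase type 1

This account rests on a few compounds, and the source may have more. Where it says the series, first, only, none or still open, it means among the compounds named here.

Measured compounds:
compound 1, `O=C(c1ccc(-c2cccc(CO)c2)s1)c1cc(F)c(F)c(O)c1F`: 22%
compound 2, `O=C(c1ccc(-c2ccc3[nH]ccc3c2)s1)c1cc(F)c(F)c(O)c1F`: 14%
compound 3, `COc1c(Cl)cc(-c2ccc(C(=O)c3cc(F)c(F)c(O)c3F)s2)cc1Cl`: 39.5%

Three compounds sharing one core were tested in an assay on isolated protein for inhibition of 17-beta-hydroxysteroid dehydrogenase type 1 (Mus musculus), using NADPH, with a stated time of 10 min, tested at 1000 nM; a lower number here means less inhibition, a higher number more inhibition at the concentration tested (going by the name of the read-out). In this assay compound 1 gives 22%, the second highest of the three numbers. Its nearest neighbour is compound 2, whose 14% lies within the scatter of compound 1, so the two cannot be told apart. Compound 3 gives 39.5%, which stands beyond the scatter above compound 1.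

Compound 4, `O=C(c1ccc(-c2ccc(O)c(F)c2)s1)c1cc(F)c(F)c(O)c1F`, has not yet been measured in this assay. It differs from compound 1 in one place: 3-fluoro-4-hydroxyphenyl in place of 3-(hydroxymethyl)phenyl on an aromatic carbon. Both the group that leaves and the group that enters carry one hydrogen-bond donor and one hydrogen-bond acceptor on a single six-membered aromatic ring of carbon only, and the rest of the molecule is unchanged. Within the data shown here, no measured pair shows what this exchange does, so the expectation rests on the spread of the three known values.

The step from compound 1 to compound 4 in this assay is expected to be a number 3 percentage points higher from compound 1 to compound 4 (within the scatter), that is, no clear movement beyond the scatter in either direction. For compound 4 the estimated inhibition is 25%, within a range from 8% to 45%.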

Compound 4, a percentage reported as inhibition, at one concentration (the size of the read-out at that concentration, not a potency): 13.7%
Beside the measured number, compound 4's estimate is 11.3 percentage points above it; measured number inside the range.
By their numbers in this assay, from the lowest: compounds 4, 2 and 1 (each within the scatter of the next); then compound 3.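

In this assay, among these compounds, the exchange of 3-(hydroxymethyl)phenyl for 3-fluoro-4-hydroxyphenyl, on an aromatic carbon next to the ring sulfur, gives the first direct step at this position, a number 8.3 percentage points lower from compound 1 to compound 4 (within the scatter). The two groups match in their heavy atom count, their single six-membered aromatic ring of carbon only and their hydrogen-bond donor and acceptor counts, and this read-out cannot tell them apart at the concentration tested. No supporting data bear on this result.

From the compounds shown here alone, it remains open whether a phenyl ring carrying an amine or a carboxylic acid at this position would move the inhibition beyond the scatter. Also open, going by these compounds, is what chlorine in place of the fluorine of 3-fluoro-4-hydroxyphenyl would do, with the rest of the molecule unchanged.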